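From 2-Methoxyphenoxy to Cyclohexyl on the Shared Core

The compounds below may be only part of what the source reports. "The series", "measured", "known", "first", "only" and "open" are said of these compounds alone.

Compound 1 `Fc1ccc(Oc2ccc3c(NCCCNCc4ccco4)ccnc3c2)cc1` and compound 2 `COc1ccccc1Oc1ccc2c(NCCCNCc3ccco3)ccnc2c1` share a core and a chain, and they differ only in the aryl group attached through an oxygen on the aromatic ring. In a physicochemical assay for acid dissociation, compound 1 gives 9.28 and compound 2 gives 9.28. The step of no change at the digits printed from compound 1 to compound 2 (within the scatter) shows that swapping one aryl group for another at that oxygen leaves the measured value where it was, so compound 2 stands level with compound 1.

Compound 3 `c1coc(CNCCCNc2ccnc3cc(C4CCCCC4)ccc23)c1` carries the change (cyclohexyl in place of 2-methoxyphenoxy on an aromatic carbon). Here the whole 2-methoxyphenoxy group leaves and a cyclohexyl ring enters on an aromatic carbon that is part of a fused or bridged system of two rings. Among the compounds with values here, the only step measured so far, no change at the digits printed from compound 1 to compound 2 (within the scatter), changed the group at this same part of the molecule without moving the value, and the chain that holds the amine is untouched. For compound 3 a step of no more than the usual scatter is therefore expected, a number 0.02 log units higher from compound 2 to compound 3 (within the scatter). Compound 3 is estimated at 9.3 in this assay, with a likely range from 9 to 9.6.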

Compound 3, acid dissociation constant: 9.47
Estimate against measurement, compound 3: 0.17 log units below; the measured number falls inside the stated range.
By their numbers in this assay, from the lowest: compounds 1, 2 and 3 (each within the scatter of the next).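

Compound 3 goes further than the earlier swap of one aryl group for another on the oxygen: the oxygen link and the aromatic ring leave together, and a non-aromatic cyclohexyl ring sits on the aromatic carbon instead. Even so, this assay gives a number 0.19 log units higher from compound 2 to compound 3 (within the scatter) and a number 0.19 log units higher from compound 1 to compound 3 (within the scatter), so the three compounds cannot be told apart by this read-out. At this position, then, the value stays within the scatter for a group with an oxygen link and hydrogen-bond acceptors and for an all-carbon ring with no hydrogen-bond acceptors, although this holds only for these three compounds, and no available evidence accounts for the result.

The compounds shown leave open what an amine or a carboxylic acid on this same aromatic carbon would do to the number, since all three groups here are neutral and each contains a six-membered ring. They also share one chain holding the amine, so the effect of a longer chain at that part of the molecule remains an open question.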